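The source may hold more compounds than are shown below. What is called first, only, known or untested is meant among the compounds shown, and "the series" means these compounds.

Among the measured compounds shown here, in a functional assay on MDA-MB-231 cells (Homo sapiens) for antiproliferative activity, read by sulforhodamine B assay, with a stated time of 48 h (a lower number here means a stronger inhibitor of growth, a higher number a weaker inhibitor of growth), three compounds with a shared core have numbers so far. Compound 1 `Cc1ccc(-c2cn(CCCN3C(=O)COc4ccccc43)nn2)cc1` gives 1120 nM, compound 2 `CCCCCc1ccc(-c2cn(CCCN3C(=O)COc4ccccc43)nn2)cc1` gives 5000 nM, and compound 3 `COc1ccc(-c2cn(CCCN3C(=O)COc4ccccc43)nn2)cc1` gives 41500 nM. That last number is the highest of the three, which makes compound 3 the weakest inhibitor of growth in this small set.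

Compound 4 `O=C1COc2ccccc2N1CCCn1cc(-c2ccccn2)nn1` keeps the core but has pyridin-2-yl in place of 4-methoxyphenyl on an aromatic carbon. For the measured compounds named here, no measured compound has a hetero atom in this aromatic ring, so the measured steps offer only indirect guidance. The most relevant are a 37-fold higher number from compound 1 to compound 3 (1.57 log units; beyond the scatter) and an 8.3-fold higher number from compound 2 to compound 3 (0.92 log units; beyond the scatter), the two steps that bring in methoxy. Both are beyond the scatter, and both move toward a weaker inhibitor. Compound 4 has no methoxy, but it also lacks the methyl and pentyl groups, so only a partial return toward lower numbers seems reasonable in this assay. The expected change is a 4.2-fold lower number from compound 3 to compound 4 (0.62 log units; beyond the scatter). For compound 4, the estimated value is 10000 nM, with an expected range from 2500 nM to 40000 nM.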

Compound 4, concentration for 50% growth inhibition: 4800 nM
Beside the measured number, compound 4's estimate is 2.1-fold (0.32 log units) above it; low and high end bracket the measured number.
By their numbers in this assay, from the lowest: compound 1; then compounds 4 and 2 (each within the scatter of the next); then compound 3.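

In this assay, a ring with a hetero atom can sit at this position on the five-membered aromatic ring with 3 nitrogen: pyridin-2-yl in place of 4-methoxyphenyl gives an 8.6-fold lower number from compound 3 to compound 4 (0.94 log units; beyond the scatter). The same ring does not match the 4-methylphenyl group, since pyridin-2-yl in its place gives a 4.3-fold higher number from compound 1 to compound 4 (0.63 log units; beyond the scatter), so compound 1 keeps the lowest number of the set. The two steps therefore show that the outcome depends on which group leaves, and nothing measured here accounts for either of them.

Going by these compounds, whether pyridin-3-yl or pyridin-4-yl would read like pyridin-2-yl remains open, as does how a plain phenyl ring would compare with all of these. Also open, on these data alone, is how an amine or a carboxylic acid on this ring would behave in this assay.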